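Aryl urea series: whole-organism readout, working notes

The compounds below may be only part of what the source reports. "The series", "measured", "known", "first", "only" and "open" are said of these compounds alone.

Three compounds have been measured in an ADME assay on the whole organism with Oryza sativa as the target, tested at 0.1 uM; a lower number here means a stronger effect, a higher number a weaker effect of the compound at the concentration tested:

Compound 1, `Cc1cccc(NC(=O)N[C@H](C)c2ccccc2)c1`, gives 100%.
Compound 2, `C[C@@H](NC(=O)Nc1cccc(F)c1)c1ccccc1`, gives 99%.
Compound 3, `C[C@@H](NC(=O)Nc1ccc(F)cc1F)c1ccccc1`, gives 100%.

Compound 2 and compound 1 differ in one place: methyl in place of fluoro on an aromatic carbon. The step is a number 1 percentage points higher from compound 2 to compound 1 (within the scatter). Compound 3 stands level with compound 1 at the digits reported, and its reading and that of compound 2 lie within the scatter of one another. The difference between the core of compound 3 and the core of compound 2 is not broken down here.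

Compound 4, `Cc1ccc(NC(=O)N[C@H](C)c2ccccc2)c(F)c1`, has not yet been measured in this assay. From compound 3 it differs by methyl in place of fluoro on an aromatic carbon. This is the same kind of change as that from compound 2 to compound 1, though the surroundings are not identical: in the earlier pair the entering methyl sits meta to a large group, whereas in compound 4 it sits meta to a fluoro group and para to a large group.

Among the compounds with values here, the one earlier instance of this change moved the reading only within the scatter. On that basis the expected step is no change at the digits printed from compound 3 to compound 4 (within the scatter). Compound 4 is therefore estimated at 100%, with a range from 92% to 103%. This rests on the earlier step of a number 1 percentage points higher from compound 2 to compound 1 (within the scatter) lying within the scatter and on compound 3 standing at 100%.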

Compound 4, a percentage reported as activity, at one concentration (the size of the read-out at that concentration, not a potency): 98%
Beside the measured number, compound 4's estimate is 2 percentage points above it; low and high end bracket the measured number.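

In this assay, methyl in place of fluoro on an aromatic carbon gives a number 2 percentage points lower from compound 3 to compound 4 (within the scatter), and the two instances of this change do not differ beyond what repeated measurement allows: the same change on two cores in this assay, a number 1 percentage points higher (within the scatter) from compound 2 to compound 1 and a number 2 percentage points lower (within the scatter) from compound 3 to compound 4, 3 percentage points apart, within the scatter of two such steps.

On these two cores, then, the change carries over without a step that can be told from the scatter, including where the entering methyl sits meta to a fluoro group and para to a large group. This does not show that the swap is neutral across the series: two pairs are a small sample, and both sit at the weak-effect end of the scale, so neither tests whether the change would carry over on a core with a clear effect.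

The compounds shown leave open whether a different group on this aromatic ring, such as a methoxy group, a nitrile or an amine, would shift the reading in this assay. Also open, as far as these compounds go, is whether a carboxylic acid or a longer chain elsewhere on the shared core would give a stronger effect, and how the readings would behave at other concentrations.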